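The compounds below may be only part of what the source reports. "The series", "measured", "known", "first", "only" and "open" are said of these compounds alone.

The three measured compounds share one core, carried by compound 1 `COc1cc(-c2nn(-c3cccc(NC(=O)c4cccc(C(F)(F)F)c4)c3)cc2-c2ccncc2)ccc1Cl`, compound 2 `COc1cc(-c2nn(-c3cccc(NC(=O)Nc4ccc(Cl)c(Cl)c4)c3)cc2-c2ccncc2)ccc1Cl` and compound 3 `COc1cc(-c2nn(-c3cccc(NC(=O)Nc4cccc(C(F)(F)F)c4)c3)cc2-c2ccncc2)ccc1Cl`. In a functional assay on TK-10 cells (Homo sapiens) for inhibition, read by sulforhodamine B assay, with a stated time of 48 h (on this read-out higher numbers stand for weaker inhibition of growth and lower numbers for stronger inhibition of growth), compound 1 gives 3240 nM, compound 2 gives 1430 nM and compound 3 gives 1310 nM. Compound 3 thus shows the lowest number of the three, but the gap to compound 2 lies within the scatter, so those two cannot be ordered; only compound 1 stands clearly apart, as the step of a 2.5-fold lower number from compound 1 to compound 3 (0.39 log units; beyond the scatter) shows. Compound 4 `COc1cc(-c2nn(-c3cccc(NC(=O)c4ccc(Cl)c(C(F)(F)F)c4)c3)cc2-c2ccncc2)ccc1Cl` differs from compound 3 in one place: 4-chloro-3-(trifluoromethyl)phenyl in place of (3-(trifluoromethyl)phenyl)amino on a carbonyl carbon. The step that bears most on this change is a 2.5-fold lower number from compound 1 to compound 3 (0.39 log units; beyond the scatter). Among the measured compounds shown here, it is the same exchange on the carbonyl carbon run in the other direction; compound 4 reverses it, except that the group that enters is 4-chloro-3-(trifluoromethyl)phenyl, and for that chlorine the set holds no measured step. The step of a 2.3-fold lower number from compound 1 to compound 2 (0.36 log units; beyond the scatter) points the same way. Compound 4 is therefore expected to move back toward the number of compound 1, with a step of a 2.3-fold higher number from compound 3 to compound 4 (0.36 log units; beyond the scatter). In this assay compound 4 is estimated at 3000 nM, with a range from 1200 nM to 7500 nM.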

Compound 4, concentration for 50% growth inhibition: 20400 nM
Compound 4: the middle estimate sits 6.8-fold (0.83 log units) below what was measured; measured number above the stated range.
By their numbers in this assay, from the lowest: compounds 3 and 2 (each within the scatter of the next); then compound 1; then compound 4.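

Among the compounds shown here, the chloro group on the aromatic carbon, the only difference between compound 1 and compound 4, proves to matter in its own right, with a 6.3-fold higher number from compound 1 to compound 4 (0.80 log units; beyond the scatter) in this assay, something the earlier compounds could not show. With that chloro group on board, the exchange at the carbonyl carbon, whose other neighbour is the amide-type nitrogen, separates compound 4 widely from both amino-bearing compounds, with a 16-fold higher number from compound 3 to compound 4 (1.19 log units; beyond the scatter) and a 14-fold higher number from compound 2 to compound 4 (1.15 log units; beyond the scatter) on the same read-out. Nothing available here accounts for the size of these steps.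

Going by these compounds, whether the same chloro group would count as heavily on a compound keeping the (3-(trifluoromethyl)phenyl)amino group remains open. So does whether a fluoro or a nitrile in place of that chloro group would give a similar step.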